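This account rests on a few compounds, and the source may have more. Where it says the series, first, only, none or still open, it means among the compounds named here.

Among the measured compounds shown here, compound 3, with the structure `COC(=O)c1c(Br)cccc1OC(=O)COc1cc(O)c2c(=O)cc(-c3ccccc3)oc2c1`, gives 41700 nM in a functional assay on cells (T-cell, Mus musculus, strain BALB/c) for inhibition, read by MTT assay, with a stated time of 72 h (a higher number here means a weaker inhibitor, a lower number a stronger inhibitor), the highest of the three numbers measured so far. Compound 2 `COC(=O)c1cccc(C)c1OC(=O)COc1cc(O)c2c(=O)cc(-c3ccccc3)oc2c1` gives 39100 nM, and the gap a 1.1-fold higher number from compound 2 to compound 3 (0.03 log units; within the scatter) does not separate the two. Compound 1 `COC(=O)c1cc(Cl)ccc1OC(=O)COc1cc(O)c2c(=O)cc(-c3ccccc3)oc2c1` gives 3740 nM, far lower than either, and the steps of a 10-fold higher number from compound 1 to compound 2 (1.02 log units; beyond the scatter) and an 11-fold higher number from compound 1 to compound 3 (1.05 log units; beyond the scatter) show that where the substituent sits on the aryl ester, rather than whether it is chlorine, bromine or methyl, governs the number.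

Compound 4 `COC(=O)c1cc(Br)ccc1OC(=O)COc1cc(O)c2c(=O)cc(-c3ccccc3)oc2c1` has the same atoms as compound 3, joined differently: a group of 11 heavy atoms (8 carbon, 2 oxygen, 1 bromine; one six-membered aromatic ring of carbon only) in place of a group of 11 heavy atoms (8 carbon, 2 oxygen, 1 bromine; one six-membered aromatic ring of carbon only), on an oxygen next to a carbonyl group. The incoming 4-bromo-2-(methoxycarbonyl)phenyl group mirrors the arrangement of compound 1, with bromine in place of chlorine. The steps from compound 1 to compound 2 and to compound 3 are the relevant ones, and they were large. Compound 4 is therefore expected to move back toward compound 1, a step of a 9.3-fold lower number from compound 3 to compound 4 (0.97 log units; beyond the scatter), an estimated 4500 nM, with a range from 1500 nM to 14000 nM.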

Compound 4, half-maximal inhibitory concentration: 780 nM
Beside the measured number, compound 4's estimate is 5.8-fold (0.76 log units) above it, and the stated range ends above it.
By their numbers in this assay, from the lowest: compound 4; then compound 1; then compounds 2 and 3 (each within the scatter of the next).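

In this assay, rearranging the same atoms into the 4-bromo-2-(methoxycarbonyl)phenyl group gives a 53-fold lower number from compound 3 to compound 4 (1.73 log units; beyond the scatter) with the halogen unchanged, so the arrangement on the aryl ester can govern the number on its own. The comparison with the methyl compound also gives a large step, a 50-fold lower number from compound 2 to compound 4 (1.70 log units; beyond the scatter) and this places the bromo compound far ahead of it. The element is not irrelevant either, as bromo in place of chloro on an aromatic carbon gives a 4.8-fold lower number from compound 1 to compound 4 (0.68 log units; beyond the scatter) and this modest step, beyond the scatter, qualifies the earlier reading that only the arrangement counted.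

From the compounds shown here alone, it remains open whether a fluoro group, an iodo group or an amine in place of the bromine would lower the number further. Nothing available here explains why either change moves the number.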